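Swapping the thiourea arm on the hydroxybenzyl analogue

A few compounds are considered here, and "the series" means these few. Any claim that something is new, unique, unknown or untested is made for them only; others in the source may bear on it.

Compound 1 `O=[N+]([O-])c1cccc(NC(=S)NCCNS(=O)(=O)c2ccc(-c3ccccc3OCc3ccccc3)s2)c1` is the reference point of this small set. In a functional assay on RS4-11 cells (Homo sapiens) for inhibition, read by CCK-8 assay, with a stated time of 48 h (a higher number here means a weaker inhibitor, a lower number a stronger inhibitor), compound 1 gives 11600 nM. Compound 2 `Cc1cc(C)cc(NC(=O)NCCNS(=O)(=O)c2ccc(-c3ccccc3OCc3ccccc3)s2)c1` carries a group of 11 heavy atoms (9 carbon, 1 nitrogen, 1 oxygen; one six-membered aromatic ring of carbon only) in place of a group of 12 heavy atoms (7 carbon, 2 nitrogen, 2 oxygen, 1 sulfur; one six-membered aromatic ring of carbon only), on an amine nitrogen. For compound 2 the reading in this assay is a limit of the assay, > 50000 nM. That change produced a step of an at least 4.3-fold higher number from compound 1 to compound 2 (0.63 log units; beyond the scatter), whose true size is bounded only by the limit of > 50000 nM in this assay, at which 1 of the 3 values shown sits. Compound 3 `O=[N+]([O-])c1cccc(NC(=S)NCCNS(=O)(=O)c2ccc(-c3ccccc3OCc3cccc(O)c3)s2)c1` differs from compound 1 by hydroxy in place of hydrogen on an aromatic carbon. In this assay compound 3 gives 9800 nM, a step of a 1.2-fold lower number from compound 1 to compound 3 (0.07 log units; within the scatter). Compound 4 `Cc1cc(C)cc(NC(=O)NCCNS(=O)(=O)c2ccc(-c3ccccc3OCc3cccc(O)c3)s2)c1` is not yet measured; it differs from compound 3 by a group of 11 heavy atoms (9 carbon, 1 nitrogen, 1 oxygen; one six-membered aromatic ring of carbon only) in place of a group of 12 heavy atoms (7 carbon, 2 nitrogen, 2 oxygen, 1 sulfur; one six-membered aromatic ring of carbon only), on an amine nitrogen, the same change that separates compound 1 from compound 2, made at the same kind of nitrogen. Because a 1.2-fold lower number from compound 1 to compound 3 (0.07 log units; within the scatter) lies within the scatter, compound 3 is treated as a near copy of compound 1 for this purpose. Compound 4 is therefore expected to show a step of a 5.1-fold higher number from compound 3 to compound 4 (0.71 log units; beyond the scatter) in this assay, matching the loss seen from compound 1 to compound 2, with a real chance that only a limit is returned. The estimate for compound 4 in this assay is 50000 nM, ranging from 20000 nM to 150000 nM.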

Compound 4, half-maximal inhibitory concentration: 5800 nM
Compound 4: the middle estimate sits 8.6-fold (0.94 log units) above what was measured; measured number below the stated range.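

In this assay, exchanging the arm for (3,5-dimethylphenyl)carbamoyl gives a 1.7-fold lower number from compound 3 to compound 4 (0.23 log units; within the scatter), so the loss seen on the core of compound 1 does not carry over to the hydroxy-bearing core: the same change on two cores in this assay, an at least 4.3-fold higher number (0.63 log units; beyond the scatter) from compound 1 to compound 2 and a 1.7-fold lower number (0.23 log units; within the scatter) from compound 3 to compound 4, at least 7.2-fold (0.86 log units) apart, beyond the scatter of two such steps. Read the other way, the hydroxy group gives an at least 8.6-fold lower number from compound 2 to compound 4 (0.93 log units; beyond the scatter) on the (3,5-dimethylphenyl)carbamoyl arm, although it makes no difference beyond the scatter on the original arm, so the two changes do not act independently here: the same change on two cores in this assay, a 1.2-fold lower number (0.07 log units; within the scatter) from compound 1 to compound 3 and an at least 8.6-fold lower number (0.93 log units; beyond the scatter) from compound 2 to compound 4, at least 7.2-fold (0.86 log units) apart, beyond the scatter of two such steps. These four compounds show that the outcome of each change depends on the other, but not why, and the true size of both gaps remains unknown, as compound 2 gives only a limit: the limit of > 50000 nM in this assay, at which 1 of the 4 values shown sits.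

The compounds shown leave open which part of the exchange matters, the sulfur-to-oxygen change or the ring substituents, since the two always travel together here. On these data alone, it is also open whether a methoxy group or a carboxylic acid in place of the hydroxy, or a longer chain, would show the same dependence.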